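A Methyl Added to the Five-Membered Ring of Compound 2

The source may hold more compounds than are shown below. What is called first, only, known or untested is meant among the compounds shown, and "the series" means these compounds.

Compound 1 `COc1ccc(-c2cc(-c3ccc([N+](=O)[O-])cc3)on2)cc1`: > 100000 nM
Compound 2 `Oc1ccc(-c2cc(-c3ccc(O)cc3)on2)cc1`: 6000 nM

For the measured compounds named here, in a functional assay on HeLa cells (Homo sapiens) for antiproliferative activity, read by cell counting, with a stated time of 5 days (a lower number here means a stronger inhibitor, a higher number a weaker inhibitor), compound 2 gives 6000 nM, the only plain number among the two values. Compound 1 sits at the limit of > 100000 nM in this assay, at which 1 of the 2 values shown sits, which is a limit of the assay and not a number. Compound 3 `Cc1c(-c2ccc(O)cc2)noc1-c1ccc(O)cc1` differs from compound 2 by methyl in place of hydrogen on an aromatic carbon. Going by the values given here, no step between measured compounds is available to set a scale for such a change. In this assay this change is expected to stay within the usual scatter, in no fixed direction. Compound 3 is therefore estimated at 6000 nM, in the range 1500 nM to 25000 nM. The expected step is no change at the digits printed from compound 2 to compound 3 (within the scatter).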

Compound 3, half-maximal inhibitory concentration: 15000 nM
Estimate against measurement, compound 3: 2.5-fold (0.40 log units) below; measured number inside the range.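

Methyl in place of hydrogen on the aromatic carbon of the five-membered ring gives a 2.5-fold higher number from compound 2 to compound 3 (0.40 log units; beyond the scatter) in this assay. For the compounds shown here, this is the first step that puts a size on any change at this position: the inhibitor grows weaker, but compound 3 still gives a plain number and not a limit. Nothing shown gives a cause for this step.

The compounds shown leave open how an ethyl chain, a chlorine atom or an amine on this carbon would read. One step also cannot tell whether activity falls further as the group on this carbon grows longer.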